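The source may report more compounds than this note shows. Statements on the series, on what has been measured and on what is new or still open speak of the compounds shown alone.

Series notes on cytotoxicity in a functional assay on SW-620 cells (Homo sapiens) for cytotoxicity, read by sulforhodamine B assay, with a stated time of 48 h, tested at 0.001 uM; on this read-out higher numbers stand for a weaker effect at the one concentration tested and lower numbers for a stronger effect.

compound 1, `COc1cc(C)cc(-c2c(-c3ccnc(-c4ccc(C(C)=O)cc4)c3)cnn2CC#N)c1`: 96%
compound 2, `COc1cc(C)cc(-c2nn(CC#N)cc2-c2ccc(-c3cccc(C(C)=O)c3)nc2)c1`: 96%
compound 3, `Cc1cc(O)cc(-c2nn(CC#N)cc2-c2ccnc(-c3ccc(Oc4ccccc4)cc3)c2)c1`: 93%

Compound 1 sits level with compound 2 at the digits given, and the number for compound 3 differs from it only within the usual scatter of this assay. Among the measured compounds shown here, all three readings are close to full activity remaining at the single low concentration tested, so the shared core of compound 1 with its nitrile-bearing chain and the pyridine-linked aryl group shows no measurable effect here in any of the three measured members. For the measured compounds named here, no pair of measured compounds differs in only one place, so no single structural step has a known size in this assay.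

The next compound, compound 4, `COc1cc(C)cc(-c2c(-c3ccnc(-c4ccc(N(C)C)cc4)c3)cnn2CC#N)c1`, is derived from compound 1 by one change: dimethylamino in place of acetyl on an aromatic carbon. Going by the values given here, nothing among the measured compounds gives this change a direction; the three readings of compound 1, compound 2 and compound 3 are all within scatter of one another despite differing aryl substituents. The expectation is therefore no step beyond the scatter in this assay, that is, an expected step of a number 1 percentage points lower from compound 1 to compound 4 (within the scatter). Compound 4 is expected to read about 95%, within a range of 85% to 102%.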

Compound 4, a percentage reported as activity, at one concentration (the size of the read-out at that concentration, not a potency): 105%
Compound 4: the middle estimate sits 10 percentage points below what was measured, outside the stated range (above it).
By their numbers in this assay, from the lowest: compounds 3, 1, 2 and 4 (each within the scatter of the next, the first and the last beyond it).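

In this assay, among the compounds shown here, putting 4-(dimethylamino)phenyl in place of 4-acetylphenyl gives a number 9 percentage points higher from compound 1 to compound 4 (within the scatter), and this is the only step with a known size. At this position, on an aromatic carbon para to a large group, acetyl and dimethylamino therefore cannot be told apart at the single low concentration tested, although one group carries a carbonyl oxygen and the other a nitrogen, with equal heavy-atom and hydrogen-bond acceptor counts. No measurement of any property of the two groups is available to bear on this result.

The compounds shown leave open whether another group at this position, such as a primary amine, a carboxylic acid or a morpholine ring, would also stay within the scatter of compound 1 in this assay. For the compounds shown here, they also leave open whether acetyl and dimethylamino would still read alike at higher concentrations, since a single low concentration gives no potency for either compound.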